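This account rests on a few compounds, and the source may have more. Where it says the series, first, only, none or still open, it means among the compounds named here.

Compound 1 `O=C(N/N=C/c1cccc(Br)c1)Nc1ccc(Oc2ccnc3[nH]ccc23)c(F)c1`: 4020 nM
Compound 2 `O=C(N/N=C/c1ccc(Br)cc1)Nc1ccc(Oc2ccnc3[nH]ccc23)c(F)c1`: 920 nM
Compound 3 `N#Cc1ccc(/C=N/NC(=O)Nc2ccc(Oc3ccnc4[nH]ccc34)c(F)c2)cc1`: 9030 nM

All three share one core and differ only in the aryl group on a carbon with a double bond to nitrogen. In a functional assay on PC-3 cells (Homo sapiens) for antiproliferative activity, read by MTT assay, with a stated time of 72 h (on this read-out higher numbers stand for weaker inhibition and lower numbers for stronger inhibition), compound 1 gives 4020 nM, the second highest of the three numbers. Compound 2 lies well below it, a 4.4-fold lower number from compound 1 to compound 2 (0.64 log units; beyond the scatter), while compound 3 lies above it, a 2.2-fold higher number from compound 1 to compound 3 (0.35 log units; beyond the scatter). Compound 4 `O=C(N/N=C/c1ccc(F)cc1Cl)Nc1ccc(Oc2ccnc3[nH]ccc23)c(F)c1` has not yet been measured; it differs from compound 1 as follows: 2-chloro-4-fluorophenyl in place of 3-bromophenyl on a carbon with a double bond to nitrogen. Both measured steps bear on this change, since each swaps one aryl group for another on the same carbon, and both were modest, pointing in opposite directions. The step expected for compound 4 is therefore small, a 1.6-fold lower number from compound 1 to compound 4 (0.21 log units; within the scatter), with a modest move either way possible. The estimate for compound 4 in this assay is 2500 nM, within 800 nM to 8000 nM.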

Compound 4, half-maximal inhibitory concentration: 3 nM
Beside the measured number, compound 4's estimate is 830-fold (2.92 log units) above it; the measured number lies below the stated range.
By their numbers in this assay, from the lowest: compound 4; then compound 2; then compound 1; then compound 3.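

In this assay, among these compounds, the aryl group on a carbon with a double bond to nitrogen proves far more decisive than the earlier swaps suggested: 2-chloro-4-fluorophenyl in place of 3-bromophenyl gives the largest step so far (a 1300-fold lower number from compound 1 to compound 4 (3.13 log units; beyond the scatter)). The same group also stands far apart from the 4-bromophenyl (a 310-fold lower number from compound 2 to compound 4 (2.49 log units; beyond the scatter)) and 4-cyanophenyl (a 3000-fold lower number from compound 3 to compound 4 (3.48 log units; beyond the scatter)) compounds. No measurement shown here accounts for this jump.

The compounds shown leave open whether the chlorine or the fluorine of the entering group carries this step. They also leave open whether a methoxy group or an amine in their stead would keep it.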